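Furan-2-yl in place of thiophen-3-yl: working notes

The source may report more compounds than this note shows. Statements on the series, on what has been measured and on what is new or still open speak of the compounds shown alone.

Measured in a functional assay on A549 cells (Homo sapiens) for cytotoxicity, with a stated time of 60 h (on this read-out lower numbers stand for an effect already at smaller amounts and higher numbers for an effect only at larger amounts of compound), and read as follows:
- compound 1 (`CCN(CC)C(=O)c1c(NC(=O)c2cccs2)sc(C)c1C`) gives (> 30000 nM), which is a limit of the assay and not a number
- compound 2 (`CCN(CC)C(=O)c1c(NC(=O)c2ccsc2)sc2c1CCCC2`) gives (29400 nM)

Among the measured compounds shown here, compound 2 holds the only number so far, and that number lies close to the limit of the read-out (the limit of > 30000 nM in this assay, at which 1 of the 2 values shown sits).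

Compound 3 (`CCN(CC)C(=O)c1c(NC(=O)c2ccco2)sc2c1CCCC2`) carries furan-2-yl in place of thiophen-3-yl on a carbonyl carbon. Both groups are one five-membered aromatic ring with 1 hetero atom.

For the measured compounds named here, no measured pair differs in one place only, so the size of a single change is not yet known. With compound 2 at (29400 nM) as the only anchor, no change beyond the usual scatter is expected in this assay for this swap. The estimated step runs (a 1.1-fold lower number from compound 2 to compound 3 (0.02 log units; within the scatter)). Compound 3 is expected at (28000 nM), with an estimated range from 14000 nM to 50000 nM in this read-out. A report as a limit alone would also fit this expectation.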

Compound 3, half-maximal effective concentration: > 30000 nM
Compound 3: only a limit was reported (the forecaster's own chance of this, stated with the estimate: 55%); at least 1.0-fold (0.02 log units) between middle value and limit.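

In this assay compound 3 gives > 30000 nM, which is a limit and not a number. Furan-2-yl in place of thiophen-3-yl on a carbonyl carbon provides the first change in this series confined to one place, and it reads an at least 1.0-fold higher number from compound 2 to compound 3 (0.00 log units; that floor lies within the scatter); only a floor is available, so the true size of the step has no upper bound. At this position, the swap between these two five-membered aromatic rings gives no sign of an effect at smaller amounts, and the read-out has little room left to show a change in that direction: the limit of > 30000 nM in this assay, at which 2 of the 3 values shown sit.

On these data alone, how far compound 3 lies past its limit remains unknown, so the furan-2-yl and thiophen-3-yl groups cannot be separated on this evidence. As far as these compounds go, it also remains open whether a different group on this carbonyl carbon, such as an aminomethyl-substituted phenyl ring or a carboxylic acid-bearing chain, would bring the values clear of the limit and give steps of readable size.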